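The compounds below may be only part of what the source reports. "The series", "measured", "known", "first", "only" and "open" are said of these compounds alone.

Working notes on the cytotoxicity series.

Of the compounds shown here, two of the shared core have numbers so far. Compound 1 `N=c1c(=O)[nH]nc2n1CCN2c1cccc(Cl)c1` is tested in an ADME assay on Vero cells (Chlorocebus sabaeus) for cytotoxicity, with a stated time of 72 h, tested at 50 ug/mL (a lower number here means a weaker effect, a higher number a stronger effect of the compound at the concentration tested), and gives 0%. Compound 2 `COc1ccccc1N1CCn2c1n[nH]c(=O)c2=O` in this assay gives 17%. Among the measured compounds shown here, compound 1 therefore stands at the lower of the two numbers, and the gap up to compound 2 lies beyond the usual scatter; no step between compounds differing in a single place is available, so nothing more is drawn from that pair.

Compound 3 `N=c1c(=O)[nH]nc2n1CCN2c1ccccc1` is the next compound to be measured in this assay. Relative to compound 1 the change is hydrogen in place of chloro on an aromatic carbon.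

For the measured compounds named here, with no single-place step to lean on, the expectation rests on compound 1 alone. The step is expected to be small, with no shift beyond the scatter in either direction: the expected step is a number 3 percentage points higher from compound 1 to compound 3 (within the scatter). Compound 3 is accordingly estimated at 3%, within a range from -8% to 15%.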

Compound 3, a percentage reported as inhibition, at one concentration (the size of the read-out at that concentration, not a potency): 30%
Compound 3: middle estimate off by 27 percentage points, on the low side, outside the stated range (above it).
By their numbers in this assay, from the lowest: compound 1; then compound 2; then compound 3.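

In this assay, the step for hydrogen in place of chloro on an aromatic carbon is a number 30 percentage points higher from compound 1 to compound 3 (beyond the scatter) and gives the series its first single-place comparison. It shows that the read-out at this concentration is sensitive to the group at this place, meta to a large group on the six-membered aromatic ring of carbon only, with the chloro compound the lower of the pair. Nothing measured here bears on why this change moves the read-out.

Going by these compounds, whether a fluoro group, an amine or a carboxylic acid at this place would give a number nearer compound 1 or compound 3 remains open. Among the compounds shown here, also open is whether the same change would give a similar step with other groups elsewhere on the shared core, since the series so far offers only this one single-place pair.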